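Swapping a pyridine for a thiophene in an mGlu5 modulator

This account rests on a few compounds, and the source may have more. Where it says the series, first, only, none or still open, it means among the compounds named here.

Compound 1: `O=C(COCc1ccncc1)N1CCN(c2cc(Cl)ccn2)CC1` — 4200 nM
Compound 2: `O=C(COCc1cccnc1)N1CCN(c2ccc(Cl)cc2Cl)CC1` — 1090 nM

Both compounds were tested in a functional assay on HEK293 cells for positive allosteric modulation of metabotropic glutamate receptor 5 (Homo sapiens), read by FLIPR and calcium flux; a higher number here means that more compound is needed for the effect, a lower number that less compound is needed. Compound 1 gives 4200 nM. Compound 2 gives 1090 nM, the lower of the two numbers, and the gap to compound 1 lies beyond the scatter. The two compounds differ in more than one place, so these values can only be read side by side, not as a single step.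

Compound 3 is `O=C(COCc1cccs1)N1CCN(c2ccc(Cl)cc2Cl)CC1`. It differs from compound 2 in one place: thiophen-2-yl in place of pyridin-3-yl on a saturated chain carbon bound to an oxygen on a saturated carbon. The shared core is unchanged, and the replacement keeps one hydrogen-bond acceptor and no donor, though the ring shrinks from six atoms to five and the nitrogen gives way to a sulfur.

Among the compounds with values here, there is no measured step of this kind to lean on. In this assay the expected change from compound 2 is small, possibly a slight rise in the number, as a 1.5-fold higher number from compound 2 to compound 3 (0.17 log units; within the scatter), with a range wide enough to include no change at all. Compound 3 is estimated at 1600 nM, between 400 nM and 6500 nM.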

Compound 3, half-maximal effective concentration: > 310 nM
Compound 3 gave a limit, no number; the forecaster's own chance of this, stated with the estimate: 10%; the middle value lies beyond the limit too.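

In this assay compound 3 gives > 310 nM, which is a limit and not a number. The step from compound 2 to compound 3 cannot be read. The compounds shown leave open whether thiophen-2-yl in place of pyridin-3-yl raises, lowers or leaves unchanged the number seen for compound 2.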